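A few compounds are considered here, and "the series" means these few. Any claim that something is new, unique, unknown or untested is made for them only; others in the source may bear on it.

Compound 1, `CC(C)Cc1ccc(C(C)C(=O)N2CCN(c3ccccc3)CC2)cc1`, gives 4700 nM in an assay on brain for inhibition of Fatty-acid amide hydrolase 1 (Rattus norvegicus), read by scintillation counting, with a stated time of 10 min; on this read-out higher numbers stand for weaker inhibition and lower numbers for stronger inhibition.
Compound 2, `CC(C)Cc1ccc(C(C)C(=O)N2CCN(c3ccc(Cl)cc3)CC2)cc1`, gives 1700 nM.

Compound 2 holds the lowest of the two numbers measured; its nearest neighbour is compound 1, and the step of a 2.8-fold lower number from compound 1 to compound 2 (0.44 log units; beyond the scatter) lies beyond the scatter. Compound 3, `CC(C)Cc1ccc(C(C)C(=O)N2CCN(c3ccc(Cl)c(Cl)c3)CC2)cc1`, is not yet measured. It differs from compound 2 by chloro in place of hydrogen on an aromatic carbon, a second chloro on the same ring. Among the measured compounds shown here, the only step that bears on this is a 2.8-fold lower number from compound 1 to compound 2 (0.44 log units; beyond the scatter), a modest lowering on the first chloro. A smaller lowering of the same sign is therefore expected in this assay, as the step of a 1.7-fold lower number from compound 2 to compound 3 (0.23 log units; within the scatter). Compound 3 is estimated at 1000 nM, with a range from 400 nM to 3000 nM.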

Compound 3, half-maximal inhibitory concentration: 16000 nM
Compound 3: middle estimate off by 16-fold (1.20 log units), on the low side, outside the stated range (above it).
By their numbers in this assay, from the lowest: compound 2; then compound 1; then compound 3.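

In this assay, the second chloro, ortho to a chloro group and meta to a large group, reverses the sign of the first chloro's step, with a 9.4-fold higher number from compound 2 to compound 3 (0.97 log units; beyond the scatter) as the result. The lowering seen with the 4-chlorophenyl group therefore does not carry over to the 3,4-dichlorophenyl group, which instead gives a 3.4-fold higher number from compound 1 to compound 3 (0.53 log units; beyond the scatter) against the unsubstituted phenyl. Nothing available here accounts for this reversal. As far as these compounds go, whether a fluoro or methoxy group in this same place would also raise the number remains open.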